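The source may hold more compounds than are shown below. What is called first, only, known or untested is meant among the compounds shown, and "the series" means these compounds.

The series rests on a shared core, seen in compound 1 `Oc1nc2nonc2nc1Nc1ccccc1`. In an assay on mitochondria from L6 cells (Rattus norvegicus) for activation, with a stated time of 90 min (on this read-out lower numbers stand for an effect already at smaller amounts and higher numbers for an effect only at larger amounts of compound), compound 1 gives 66700 nM, the highest of the two numbers recorded so far. Among the measured compounds shown here, its only measured neighbour is compound 2 `Oc1nc2nonc2nc1Nc1ccccc1Cl`, which in this assay gives 6300 nM; the step of an 11-fold lower number from compound 1 to compound 2 (1.02 log units; beyond the scatter) comes with chloro in place of hydrogen on an aromatic carbon. Compound 3 `Oc1nc2nonc2nc1Nc1ccc(Cl)cc1` has not yet been measured in this assay. Relative to compound 1 it carries the change (chloro in place of hydrogen on an aromatic carbon). For the measured compounds named here, the one step that bears on it is the large one, an 11-fold lower number from compound 1 to compound 2 (1.02 log units; beyond the scatter), and compound 3 is therefore expected to show a lower number than compound 1, though the chlorine in compound 3 sits para to a large group rather than where it sits in compound 2, so a somewhat smaller step than that one is expected, a 4.4-fold lower number from compound 1 to compound 3 (0.65 log units; beyond the scatter). For compound 3 the estimate in this assay is 15000 nM, with a range from 4000 nM to 50000 nM.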

Compound 3, half-maximal effective concentration: 11700 nM
Beside the measured number, compound 3's estimate is 1.3-fold (0.11 log units) above it, and the stated range covers the measured number.
By their numbers in this assay, from the lowest: compounds 2 and 3 (each within the scatter of the next); then compound 1.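

In this assay, the step of a 5.7-fold lower number from compound 1 to compound 3 (0.76 log units; beyond the scatter) shows that the lower number seen with chloro in place of hydrogen is not confined to the place the chlorine occupies in compound 2: on the aromatic carbon para to a large group, the same change also gives a step beyond the scatter. Compound 3 at 11700 nM and compound 2 at 6300 nM lie within the scatter of each other, so this read-out does not separate these two placements of the chlorine. No measurement given here bears on why chloro in place of hydrogen has this effect at either place.

The compounds shown leave open whether other groups on the carbon para to a large group, such as fluoro, methoxy, an amine or a carboxylic acid, would move the number as chloro does. They also leave open whether chloro at both places together would go further than chloro at either place alone, and how changes to the shared core would read in this assay.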